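Chloro for Methyl on the Aryl Group of Compound 1

The source may hold more compounds than are shown below. What is called first, only, known or untested is meant among the compounds shown, and "the series" means these compounds.

Compound 1, `COc1ccc(/C=C2/CN(C)/C(=N/c3ccc(C)cc3)S2)cc1`: 7600 nM
Compound 2, `COc1ccc(/C=C2\S/C(=N\c3ccc(C(C)(C)C)cc3)N(C)C2=O)cc1`: > 100000 nM

Of the compounds shown here, two have been measured in a functional assay on MCF7 cells (Homo sapiens) for antiproliferative activity, read by MTT assay, with a stated time of 72 h; on this read-out higher numbers stand for weaker inhibition and lower numbers for stronger inhibition. Among the compounds with values here, compound 1 `COc1ccc(/C=C2/CN(C)/C(=N/c3ccc(C)cc3)S2)cc1` gives 7600 nM, the only number returned so far. Within the data shown here, compound 2 `COc1ccc(/C=C2\S/C(=N\c3ccc(C(C)(C)C)cc3)N(C)C2=O)cc1` returned no number but a limit, > 100000 nM, and it is the one compound that sits at the limit of > 100000 nM in this assay, at which 1 of the 2 values shown sits. Among the measured compounds shown here, no single-point step between compound 1 and compound 2 is given, so their two values are left to stand as they are.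

Compound 3 `COc1ccc(/C=C2/CN(C)/C(=N/c3ccc(Cl)cc3)S2)cc1` awaits measurement in this assay. It differs from compound 1 in one place: chloro in place of methyl on an aromatic carbon. For the measured compounds named here, no measured step bears on this change, so only a small shift is expected, either within the scatter or leaning a little toward stronger inhibition. The step expected from compound 1 to compound 3 is a 1.3-fold lower number from compound 1 to compound 3 (0.10 log units; within the scatter). Compound 3 is therefore estimated to give about 6000 nM in this assay, most likely between 2000 nM and 20000 nM.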

Compound 3, half-maximal inhibitory concentration: 7600 nM
Estimate against measurement, compound 3: 1.3-fold (0.10 log units) below; low and high end bracket the measured number.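

In this assay, within the data shown here, the change from 4-methylphenyl to 4-chlorophenyl gives no change at the digits printed from compound 1 to compound 3 (within the scatter) and so supplies the first step in which only one place differs. It shows that, on this aromatic carbon para to a large group, chloro can stand in place of methyl with no shift beyond the scatter. Nothing measured here bears on why the two groups read alike.

On these data alone, whether a hydroxyl, an amine or a carboxylic acid on this same carbon would also leave the reading within the scatter remains open. The compounds shown also leave open how far the methoxy group elsewhere in compound 1 contributes, since no step shown touches it.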